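The compounds below may be only part of what the source reports. "The series", "measured", "known", "first", "only" and "open" are said of these compounds alone.

Series notes. Compound 1 `C[C@H](NC(=O)c1cc(Cl)ccc1OCCNC(=O)OC(C)(C)C)C(=O)Nc1ccc([N+](=O)[O-])cc1Cl` carries a tert-butoxycarbonyl on an amine nitrogen; in a functional assay on MCF7 cells (Homo sapiens) for inhibition, read by MTT assay, with a stated time of 72 h (on this read-out lower numbers stand for stronger inhibition and higher numbers for weaker inhibition), compound 1 reaches only the limit > 10000 nM. Compound 2 `C[C@H](NC(=O)c1cc(Cl)ccc1OCCN)C(=O)Nc1ccc([N+](=O)[O-])cc1Cl` differs from it by hydrogen in place of tert-butoxycarbonyl on an amine nitrogen; in this assay compound 2 likewise sits at the limit > 10000 nM. The step that the two limits leave unreadable from compound 1 to compound 2 therefore stays unread. Compound 3 `CC(C)[C@H](NC(=O)c1cc(Cl)ccc1OCCNC(=O)OC(C)(C)C)C(=O)Nc1cc(C(F)(F)F)cc(C(F)(F)F)c1` rests on a core whose difference from the core of compound 1 is not broken down here; in this assay compound 3 also returns only the limit > 10000 nM. Compound 4 `CC(C)[C@H](NC(=O)c1cc(Cl)ccc1OCCN)C(=O)Nc1cc(C(F)(F)F)cc(C(F)(F)F)c1` stands to compound 3 as compound 2 stands to compound 1, the same change hydrogen in place of tert-butoxycarbonyl on an amine nitrogen at the same place. With the limit of > 10000 nM in this assay, at which 3 of the 3 values shown sit, and no readable step on record, the expected step that the limit leaves unreadable from compound 3 to compound 4 is judged to leave the value at the limit. Compound 4 is accordingly estimated at 20000 nM, between 8000 nM and 60000 nM.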

Compound 4, half-maximal inhibitory concentration: 6010 nM
Estimate against measurement, compound 4: 3.3-fold (0.52 log units) above, and the stated range ends above it.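

Hydrogen in place of tert-butoxycarbonyl on the amine nitrogen gives an at least 1.6-fold lower number from compound 3 to compound 4 (0.22 log units; that floor lies within the scatter) in this assay. On the core of compound 1, the same change leads to compound 2, which stays at the limit > 10000 nM, and that step cannot be read. A measured value thus appears on one core only, and carrying the change from one core to the other is neither confirmed nor ruled out: the limit of > 10000 nM in this assay, at which 3 of the 4 values shown sit.

Open, as far as these compounds go, is how a longer chain ending in an amine, or a carboxylic acid in place of the amine, would read on the core of compound 3. Also open, from the compounds shown here alone, is which of the differences between the two cores goes with the measured value of compound 4.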